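The compounds below may be only part of what the source reports. "The series", "measured", "known", "first", "only" and "open" are said of these compounds alone.

Compound 3 (`O=C(N/N=C/c1ccccc1)N1CCc2ncnc(Nc3cccc(Br)c3)c2C1`) gives 37800 nM in a functional assay on NCI-H1975 cells (Homo sapiens) for cytotoxicity, read by MTT assay, with a stated time of 72 h (on this read-out lower numbers stand for stronger inhibition and higher numbers for weaker inhibition), and stands level, within the scatter, with compound 2 (`O=C(N/N=C/c1ccc(C(F)(F)F)cc1)N1CCc2ncnc(Nc3ccc(F)c(Cl)c3)c2C1`), which gives 36800 nM there. Among the compounds with values here, compound 1 (`Cc1ccc(/C=N/NC(=O)N2CCc3ncnc(Nc4ccc(F)c(Cl)c4)c3C2)cc1C`) gives 6830 nM as the one clearly lower number of the three, and its gaps to the other two lie beyond the scatter.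

Compound 4 (`O=C(N/N=C/c1cccnc1)N1CCc2ncnc(Nc3cccc(Br)c3)c2C1`) differs from compound 3 in a single group, with pyridin-3-yl in place of phenyl on a carbon with a double bond to nitrogen. Within the data shown here, the only measured step at that place is a 5.4-fold higher number from compound 1 to compound 2 (0.73 log units; beyond the scatter) on exchanging 3,4-dimethylphenyl for 4-(trifluoromethyl)phenyl. It shows that a change of group there can move the number by a modest amount. However, neither compound in that step holds a ring with a hetero atom, and neither shares the full remainder of compound 3, so the data give no firm direction for this exchange.

No shift beyond the scatter is therefore expected, though a modest move either way remains possible. The expected change is a 1.4-fold lower number from compound 3 to compound 4 (0.13 log units; within the scatter) in this assay on this estimate. For compound 4 the estimated value is 28000 nM with an expected range from 9000 nM to 70000 nM in this measurement.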

Compound 4, half-maximal inhibitory concentration: > 200000 nM
Compound 4: a limit, no number (the forecaster's own chance of this, stated with the estimate: 12%); at least 7.1-fold (0.85 log units) between middle value and limit.
By their numbers in this assay, from the lowest: compound 1; then compounds 2 and 3 (each within the scatter of the next). At a limit, above all of these: compound 4.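

In this assay compound 4 gives > 200000 nM, which is a limit of the assay and not a number. The exchange of phenyl for pyridin-3-yl gives an at least 5.2-fold higher number from compound 3 to compound 4 (0.72 log units; beyond the scatter), so at this place, on a carbon with a double bond to nitrogen, replacing one ring carbon with nitrogen is enough to shift the result beyond the scatter towards weaker inhibition. Within the data shown here, the earlier step at this place, a 5.4-fold higher number from compound 1 to compound 2 (0.73 log units; beyond the scatter), joined two rings of carbon only, so this is the first direction seen for a ring with a hetero atom here, and its true size stays unfixed, as it rests on a limit: the limit of > 200000 nM in this assay, at which 1 of the 4 values shown sits.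

The compounds shown leave open whether pyridin-2-yl or pyridin-4-yl, which hold the ring nitrogen elsewhere, would give the same outcome, and whether a phenyl ring carrying an amine or a carboxylic acid would behave like pyridin-3-yl. They also leave open whether the same exchange would give a similar step on the core of compound 1, since it has been read only on the core of compound 3.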